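Replacing a Methyl with Oxadiazole on a Pyridine Ring

This account rests on a few compounds, and the source may have more. Where it says the series, first, only, none or still open, it means among the compounds named here.

Measured compounds:
Compound 1, `Cc1cccnc1-c1ccc(C(=O)Nc2ccc(C(C)(C)C)cc2)cc1`: 11 nM
Compound 2, `CN(C)Cc1cccnc1-c1ccc(C(=O)Nc2ccc(C(C)(C)C)cc2)cc1`: 746 nM

In a functional assay for antagonist activity at transient receptor potential cation channel subfamily V member 1 (Homo sapiens), read by FLIPR (on this read-out higher numbers stand for weaker inhibition and lower numbers for stronger inhibition), compound 1 gives 11 nM and stands lowest of the two numbers recorded; its nearest neighbour is compound 2, which gives 746 nM. Going by the values given here, the one measured step is a 68-fold higher number from compound 1 to compound 2 (1.83 log units; beyond the scatter). The structural change in that step is dimethylamino in place of hydrogen on a saturated chain carbon bound to an aromatic carbon.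

Compound 3, `CC(C)(C)c1ccc(NC(=O)c2ccc(-c3ncccc3-c3nnco3)cc2)cc1`, is not yet measured. It differs from compound 1 by 1,3,4-oxadiazol-2-yl in place of methyl on an aromatic carbon. Among the compounds with values here, both this change and the step from compound 1 to compound 2 alter the same methyl group of compound 1, so that step is the only guide, and it was large. The change here puts a different kind of group at that spot, so a loss of a smaller size is expected, though the direction is uncertain. Compound 3 is therefore estimated at 120 nM, within 25 nM to 700 nM, an expected step of an 11-fold higher number from compound 1 to compound 3 (1.04 log units; beyond the scatter).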

Compound 3, half-maximal inhibitory concentration: 91 nM
For compound 3 the middle estimate is 1.3-fold (0.12 log units) above the measured one, within the range that was stated.
By their numbers in this assay, from the lowest: compound 1; then compound 3; then compound 2.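

In this assay, the spot that holds the methyl group in compound 1 still gives a measurable number when it carries a whole five-membered aromatic ring: the 1,3,4-oxadiazol-2-yl group brings an 8.3-fold higher number from compound 1 to compound 3 (0.92 log units; beyond the scatter) and so costs inhibition without abolishing it. Against the (dimethylamino)methyl group, the same ring gives an 8.2-fold lower number from compound 2 to compound 3 (0.91 log units; beyond the scatter) and thus shows that the size of the loss here depends on which group enters. Nothing available explains why these three groups fall in this order.

Going by these compounds alone, only three groups have been compared at this spot, so one ring and one amine-bearing chain say little about the range of what is accepted. Going by these compounds, whether a chlorine atom, a phenyl ring or a carboxylic acid would stay close to compound 1 remains open.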